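Series notes: the step from compound 2 to compound 3

A few compounds are considered here, and "the series" means these few. Any claim that something is new, unique, unknown or untested is made for them only; others in the source may bear on it.

Compound 1 `Cc1cc(O)c(C2=NN(c3ccc(S(N)(=O)=O)cc3)C(c3ccccc3Cl)C2)cc1Cl` and compound 2 `COc1ccc(C2CC(c3cc(Cl)c(C)cc3O)=NN2c2ccc(S(N)(=O)=O)cc2)cc1OC` share one core and differ only in the aryl group on a saturated ring carbon, 3,4-dimethoxyphenyl in compound 2 in place of 2-chlorophenyl in compound 1. In a functional assay on SN12C cells (Homo sapiens) for antiproliferative activity, with a stated time of 48 h (on this read-out lower numbers stand for stronger inhibition of growth and higher numbers for weaker inhibition of growth), compound 1 gives 2550 nM and compound 2 gives 3700 nM. The step of a 1.5-fold higher number from compound 1 to compound 2 (0.16 log units; within the scatter) lies within the scatter, so the two cannot be ordered; compound 2 simply carries the higher of the two numbers.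

Compound 3 `COc1ccc(C2CC(c3cc(Cl)c(C)cc3O)=NN2c2ccc(S(N)(=O)=O)cc2)c(OC)c1OC` is not yet measured. It differs from compound 2 by methoxy in place of hydrogen on an aromatic carbon: the methoxy enters ortho to a large group, ortho to a methoxy group and meta to a methoxy group, so that 3,4-dimethoxyphenyl becomes 2,3,4-trimethoxyphenyl. Among the compounds with values here, the only measured step, a 1.5-fold higher number from compound 1 to compound 2 (0.16 log units; within the scatter), concerns the same aryl position and stayed within the scatter; no measured pair shows the effect of one added methoxy. The step of a 1.1-fold higher number from compound 2 to compound 3 (0.03 log units; within the scatter) is therefore expected to stay within the scatter. For compound 3 in this assay the expected value is 4000 nM, with a range from 1500 nM to 11000 nM.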

Compound 3, concentration for 50% growth inhibition: 2970 nM
Compound 3: the middle estimate sits 1.3-fold (0.13 log units) above what was measured; the measured number falls inside the stated range.
By their numbers in this assay, from the lowest: compounds 1, 3 and 2 (each within the scatter of the next).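

Within the data shown here, the first measured pair for a single added methoxy, ortho to a large group and ortho to a methoxy group, turning 3,4-dimethoxyphenyl into 2,3,4-trimethoxyphenyl, gives in this assay a step that stays inside the scatter (a 1.2-fold lower number from compound 2 to compound 3 (0.10 log units; within the scatter)), so this change has no readable consequence on this read-out. The direct exchange of 2-chlorophenyl for 2,3,4-trimethoxyphenyl on the saturated ring carbon also stays inside the scatter (a 1.2-fold higher number from compound 1 to compound 3 (0.07 log units; within the scatter)), and with this step all three aryl groups shown at this place stand within the scatter of one another, with no compound going against that and no order among them. Nothing in the available evidence bears on this result.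

The compounds shown leave open whether a group of another kind on this aryl ring, such as an amine or a carboxylic acid, or a longer chain such as butoxy in place of a methoxy, would give a step beyond the scatter. They also leave open how this read-out responds to changes elsewhere on the shared core, since all three compounds carry the same sulfonamide and the same chlorinated hydroxyphenyl group.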